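Shifting one fluorine on the sulfonyl aryl group

The source may report more compounds than this note shows. Statements on the series, on what has been measured and on what is new or still open speak of the compounds shown alone.

Among the compounds with values here, compound 1 `CC1CCN(c2c(S(=O)(=O)c3cc(F)cc(F)c3)cnc3cc(Cl)ccc23)CC1` gives 94% in an assay on isolated protein for displacement of a labelled ligand from metabotropic glutamate receptor 5 (Homo sapiens), with a stated time of 60 min, tested at 1 uM (a lower number here means less inhibition, a higher number more inhibition at the concentration tested (going by the name of the read-out)), the highest of the two numbers measured so far, while compound 2 `Cc1ccc2ncc(S(=O)(=O)c3cccc(Cl)c3)c(N3CCC(C)CC3)c2c1` gives 91%, a gap within the scatter. Compound 3 `CC1CCN(c2c(S(=O)(=O)c3ccc(F)c(F)c3)cnc3cc(Cl)ccc23)CC1` has the same atoms joined differently: 3,4-difluorophenyl in place of 3,5-difluorophenyl on a sulfonyl sulfur. Within the data shown here, no step between measured compounds matches this change, so its size is uncertain. With compound 1 already at 94%, the read-out has little room to rise, and a small loss or no change beyond the scatter is expected. Compound 3 is expected to give 88%, ranging from 74% to 99%, so that a number 6 percentage points lower from compound 1 to compound 3 (within the scatter) is expected to stay within the scatter.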

Compound 3, a percentage reported as inhibition, at one concentration (the size of the read-out at that concentration, not a potency): 90%
For compound 3 the middle estimate is 2 percentage points below the measured one; measured number inside the range.
By their numbers in this assay, from the lowest: compounds 3, 2 and 1 (each within the scatter of the next).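

In this assay, moving one fluorine on the sulfonyl aryl group gives a number 4 percentage points lower from compound 1 to compound 3 (within the scatter), so 3,4-difluorophenyl and 3,5-difluorophenyl on a sulfonyl sulfur cannot be told apart at this concentration. This single step shows that this rearrangement of the same atoms keeps the read-out high. Nothing available explains the result.

As far as these compounds go, with both compounds near the top of the read-out, any difference in potency between them remains open. Also open, from the compounds shown here alone, is how a methoxy group or a pyridine ring at this place would read.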